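Acid dissociation in the diamine series: expectation for compound 4

The source may report more compounds than this note shows. Statements on the series, on what has been measured and on what is new or still open speak of the compounds shown alone.

Compound 3 `COc1cccc(CNCCCNc2ccnc3cc(Cc4ccc(C#N)cc4)ccc23)c1O` stands level with both other measured members in a physicochemical assay for acid dissociation: compound 3 gives 9.47, compound 1 `COc1ccc(F)cc1CNCCCNc1ccnc2cc(Cc3ccc(C#N)cc3)ccc12` gives 9.47, and compound 2 `COc1cccc(CNCCCNc2ccnc3cc(-c4ccc(F)cc4)ccc23)c1O` gives 9.47. Both measured steps lie within the scatter: no change at the digits printed from compound 1 to compound 3 (within the scatter) and no change at the digits printed from compound 2 to compound 3 (within the scatter).

Compound 4 `COc1cccc(CNCCCNc2ccnc3cc(-c4cccc5ccccc45)ccc23)c1O` differs from compound 3 on an aromatic carbon: naphthalen-1-yl in place of 4-cyanobenzyl on an aromatic carbon. Going by the values given here, the measured step that bears on this is the one from compound 2 to compound 3, which also exchanged the group on that aromatic carbon and left the read-out unchanged. The step from compound 1 to compound 3 altered a group on the saturated chain carbon bound to an amine nitrogen and is of a different kind, though it too was flat.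

Compound 4 is therefore expected to show no change at the digits printed from compound 3 to compound 4 (within the scatter), no step beyond the scatter, because no change at the digits printed from compound 2 to compound 3 (within the scatter). Compound 4 is estimated at 9.47, with a range from 9.15 to 9.8.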

Compound 4, acid dissociation constant: 9.47
The estimate for compound 4 equals the measured number at the digits printed; low and high end bracket the measured number.
By their numbers in this assay, from the lowest: compounds 1, 2, 3 and 4 (each within the scatter of the next).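

In this assay, a third group on this aromatic carbon leaves the read-out level (no change at the digits printed from compound 3 to compound 4 (within the scatter)) and (no change at the digits printed from compound 2 to compound 4 (within the scatter)). Earlier compounds covered only the exchange of 4-fluorophenyl for 4-cyanobenzyl here; the series now also includes naphthalen-1-yl, with 2 six-membered aromatic rings of carbon only and 0 hydrogen-bond acceptors, in place of 4-cyanobenzyl, with its triple bond and 1 hydrogen-bond acceptor, and these differences come with no step beyond the scatter. Nothing available accounts for this flat result.

On these data alone, both 4-cyanobenzyl and naphthalen-1-yl carry no net charge, so it stays open whether a carboxylic acid or a dimethylamino group on this aromatic carbon would also leave the read-out level. Also open, as far as these compounds go, is whether a longer chain in place of the saturated chain of the shared core would do the same.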